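Changing the Ether Chain on the Shared Core

This account rests on a few compounds, and the source may have more. Where it says the series, first, only, none or still open, it means among the compounds named here.

The compounds share one core and differ in the chain on the ring oxygen and in what sits on one aromatic carbon. Compound 1 `CC(CC(C)(C)C)Oc1cccc2cccnc12` carries hydrogen at that carbon. In an assay on cells with melanin-concentrating hormone receptor 1 (Homo sapiens) as the target, read by radioligand binding (on this read-out higher numbers stand for weaker inhibition and lower numbers for stronger inhibition), compound 1 gives > 2000 nM, which is a limit of the assay rather than a number. Compound 3 `CC(CC(C)(C)C)Oc1cccc2ccc(N3CCCC3)nc12` carries pyrrolidin-1-yl in place of that hydrogen. In this assay compound 3 gives > 2000 nM, again a limit. The step that the two limits leave unreadable from compound 1 to compound 3 cannot be read because both values sit at the limit of > 2000 nM in this assay, at which 2 of the 3 values shown sit. Within the data shown here, compound 2 `CC(C)C(C)Oc1cccc2ccc(N)nc12` differs from both at that carbon and is the only compound with a true number: in this assay compound 2 gives 199 nM. Compound 4 `Nc1ccc2cccc(OCCC3CC3)c2n1` keeps the rest of compound 2 and changes only the chain on the oxygen: 2-cyclopropylethyl in place of 1,2-dimethylpropyl on an oxygen on an aromatic ring. Among the measured compounds shown here, no measured step touches this chain, and the single step that was measured lies elsewhere and is unreadable. The expectation is therefore a step of a 1.3-fold higher number from compound 2 to compound 4 (0.10 log units; within the scatter) with no clear direction beyond the scatter. Compound 4 is expected at 250 nM, with a range from 60 nM to 1000 nM.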

Compound 4, half-maximal inhibitory concentration: 492 nM
For compound 4 the middle estimate is 2.0-fold (0.29 log units) below the measured one; the measured number falls inside the stated range.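

Among these compounds, this is the first readable step at the chain on the oxygen: in this assay, 2-cyclopropylethyl in place of 1,2-dimethylpropyl gives a 2.5-fold higher number from compound 2 to compound 4 (0.39 log units; beyond the scatter), a modest change but one that lies beyond the scatter. Both chains have 5 heavy atoms, all carbon, and neither has hydrogen-bond donors or acceptors, yet only 2-cyclopropylethyl holds a three-membered ring, so rearranging the same number of carbons on the oxygen is enough to shift the number. Nothing measured here gives a reason for this step.

The compounds shown leave open whether a longer chain, or a chain ending in a carboxylic acid, would move the number further from that of compound 2. From the compounds shown here alone, the step between compound 1 and compound 3 cannot be read, so what pyrrolidin-1-yl does on the aromatic carbon also stays open.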